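A few compounds are considered here, and "the series" means these few. Any claim that something is new, unique, unknown or untested is made for them only; others in the source may bear on it.

In a functional assay on A549 cells (Homo sapiens) for cytotoxicity, read by MTT assay, with a stated time of 48 h (a higher number here means a weaker inhibitor, a lower number a stronger inhibitor), compound 1 `COc1ccc(-c2nc3ccccn3c2C(=O)/C=C\Nc2ccc3cc[nH]c3c2)cc1` gives 8800 nM and compound 2 `COc1cc(N/C=C\C(=O)c2c(-c3ccc(Cl)cc3)nc3ccccn23)cc(OC)c1` gives 9900 nM. Among the compounds with values here, compound 3 `O=C(/C=C\Nc1ccc2[nH]ccc2c1)c1c(-c2ccc(Cl)cc2)nc2ccccn12` gives 1010 nM, the lowest of the three numbers so far, and so it is the natural reference point for the next structure.

That structure is compound 4 `O=C(/C=C\Nc1ccc2cc[nH]c2c1)c1c(-c2ccc(Cl)cc2)nc2ccccn12`, which has the same atoms as compound 3, joined differently: 1H-indol-6-yl in place of 1H-indol-5-yl on an amine nitrogen. In short, 1H-indol-6-yl takes the place of 1H-indol-5-yl on an amine nitrogen, so only the attachment point on the same group moves.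

Within the data shown here, the one measured step that bears on this is a 9.8-fold lower number from compound 2 to compound 3 (0.99 log units; beyond the scatter). It shows that the group on this nitrogen can matter, but it replaces a different group and says nothing directly about moving the attachment point. Compound 1 also carries 1H-indol-6-yl and gives 8800 nM, yet it differs from compound 4 elsewhere, so it is only a weak hint toward a higher number. Among the measured compounds shown here, no measured pair isolates this change.

A small rise is therefore expected, possibly no larger than the scatter, and the expected change is a 1.8-fold higher number from compound 3 to compound 4 (0.25 log units; within the scatter). For compound 4 the estimated value is 1800 nM, with an expected range of 500 nM to 7000 nM.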

Compound 4, half-maximal inhibitory concentration: 2290 nM
Compound 4: middle estimate off by 1.3-fold (0.10 log units), on the low side; low and high end bracket the measured number.
By their numbers in this assay, from the lowest: compound 3; then compound 4; then compounds 1 and 2 (each within the scatter of the next).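

In this assay, the shift of attachment point alone gives a 2.3-fold higher number from compound 3 to compound 4 (0.36 log units; beyond the scatter), so the place where the same ring system joins the amine nitrogen counts even though no atom is added or removed. The comparison with 3,5-dimethoxyphenyl gives a 4.3-fold lower number from compound 2 to compound 4 (0.64 log units; beyond the scatter), which means that 1H-indol-6-yl also gives a lower number than that group, though by less than a 9.8-fold lower number from compound 2 to compound 3 (0.99 log units; beyond the scatter) does for 1H-indol-5-yl. With 1H-indol-6-yl held in place, the change of methoxy to chloro on an aromatic carbon gives a 3.8-fold lower number from compound 1 to compound 4 (0.58 log units; beyond the scatter), the first direct sign that this other part of the molecule also affects the number.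

No measurement here explains why either of these changes shifts the number. Also open, going by these compounds, are how fluoro or a nitrile would compare with chloro on that aromatic carbon, and whether chloro would give a similar drop relative to methoxy when 1H-indol-5-yl sits on the amine nitrogen.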